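The compounds below may be only part of what the source reports. "The series", "measured", "known", "first", "only" and "open" are said of these compounds alone.

Compound 1 `O=C(O)Cc1sc(C(c2ccc(F)cc2)c2ccc(F)cc2)nc1-c1ccnc(F)c1` and compound 2 `O=C(O)Cc1sc(C(c2ccc(F)cc2)c2ccc(F)cc2)nc1-c1ccnc(N2CCC2)c1` share a core and differ in one place, where compound 2 carries an azetidin-1-yl in place of fluoro on an aromatic carbon. In an in vitro functional assay on HEK285-7 cells for antagonist activity at prostaglandin D2 receptor 2 (Homo sapiens), read by BRET and beta-arrestin recruitment (a lower number here means a stronger inhibitor, a higher number a weaker inhibitor), compound 1 gives 4.7 nM. For compound 2 this assay reports only a limit, > 100000 nM, so compound 2 stands at the weak end of the numbers shown, with no exact value (the limit of > 100000 nM in this assay, at which 1 of the 2 values shown sits). Among the measured compounds shown here, the move between them, an at least 21000-fold higher number from compound 1 to compound 2 (4.32 log units; beyond the scatter), is the only measured step available.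

Compound 3 `O=C(O)Cc1sc(C(c2ccc(F)cc2)c2ccc(F)cc2)nc1-c1ccccc1` has not been measured. It differs from compound 2 in that place: phenyl in place of 2-(azetidin-1-yl)pyridin-4-yl on an aromatic carbon. For the measured compounds named here, because the one measured step, an at least 21000-fold higher number from compound 1 to compound 2 (4.32 log units; beyond the scatter), showed that replacing a small fluoro with the azetidin-1-yl removed activity, taking that whole 2-(azetidin-1-yl)pyridin-4-yl away and putting in a phenyl, closer in size to what compound 1 carries, is expected to recover much of it. The expected step is an at least 6600-fold lower number from compound 2 to compound 3 (3.82 log units; beyond the scatter), a large fall in the number. Compound 3 is therefore estimated at 15 nM in this assay, between 3 nM and 150 nM.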

Compound 3, half-maximal inhibitory concentration: 240 nM
Beside the measured number, compound 3's estimate is 16-fold (1.20 log units) below it; measured number above the stated range.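

In this assay, replacing the whole 2-(azetidin-1-yl)pyridin-4-yl with a plain phenyl on the aromatic carbon next to the ring nitrogen gives an at least 410-fold lower number from compound 2 to compound 3 (2.61 log units; beyond the scatter), so a ring carrying no nitrogen at this carbon still leaves a measurable inhibitor. The phenyl does not match the group in compound 1, however: the change gives a 51-fold higher number from compound 1 to compound 3 (1.71 log units; beyond the scatter), which places compound 3 in the middle of the three and shows that the 2-fluoropyridin-4-yl gives a lower number than the phenyl, something the first pair could not show. The step from compound 2 gives only a minimum size, because compound 2 has a limit rather than an exact number: the limit of > 100000 nM in this assay, at which 1 of the 3 values shown sits.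

The compounds shown cannot separate whether the ring nitrogen or the fluoro accounts for the difference between compound 1 and compound 3; a pyridin-4-yl without the fluoro, or a fluorophenyl, at this carbon would divide the two. They also leave open whether the loss in compound 2 is particular to the azetidin-1-yl, which a methoxy or a dimethylamino group in place of the fluoro would test.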